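The source may hold more compounds than are shown below. What is called first, only, known or untested is meant among the compounds shown, and "the series" means these compounds.

The measured compounds are these. Compound 1, `CCc1cc(C(C)=O)c(O)cc1OCCCC(C)(C)C#N`, gives 85% in an assay on isolated protein for inhibition of leukotriene B4 receptor 1 (Homo sapiens), tested at 10 uM; on this read-out lower numbers stand for less inhibition and higher numbers for more inhibition at the one concentration tested (going by the name of the read-out). Compound 2, `CCc1cc(C(C)=O)c(O)cc1OCCCCCCC(=O)O`, gives 87% in this assay.

Compound 2 stands highest of the two numbers, but its nearest neighbour is compound 1, and the step of a number 2 percentage points higher from compound 1 to compound 2 (within the scatter) does not separate them. Compound 3 is `CCc1cc(C(C)=O)c(O)cc1OCCCCCn1cncn1`. It differs from compound 2 by 1H-1,2,4-triazol-1-yl in place of carboxymethyl on a saturated chain carbon, five bonds along the chain from an oxygen on an aromatic ring. Going by the values given here, the only measured step, a number 2 percentage points higher from compound 1 to compound 2 (within the scatter), also altered the far end of the chain and stayed within the scatter, so no large movement is the expectation, though the change here is a different one. Compound 3 is therefore expected to give about 78%, somewhere between 50% and 95%. That expected estimate amounts to a step of a number 9 percentage points lower from compound 2 to compound 3 (within the scatter).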

Compound 3, a percentage reported as inhibition, at one concentration (the size of the read-out at that concentration, not a potency): 82%
Beside the measured number, compound 3's estimate is 4 percentage points below it; the range from low to high includes it.
By their numbers in this assay, from the lowest: compounds 3, 1 and 2 (each within the scatter of the next).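

In this assay, 1H-1,2,4-triazol-1-yl in place of carboxymethyl gives a number 5 percentage points lower from compound 2 to compound 3 (within the scatter), and 2-(1H-1,2,4-triazol-1-yl)ethyl in place of 1-cyano-1-methylethyl gives a number 3 percentage points lower from compound 1 to compound 3 (within the scatter). At this place on the chain, a five-membered aromatic ring with no hydrogen-bond donor therefore reads the same, within the scatter, as the carboxylic acid and nitrile ends. No measurement here gives a reason for this. From the compounds shown here alone, whether an amine or a shorter chain at this place would also stay within the scatter remains open. With all three compounds inside the scatter at one concentration, their chain ends cannot be ranked.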